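The source may hold more compounds than are shown below. What is called first, only, known or untested is meant among the compounds shown, and "the series" means these compounds.

In an ADME assay (liver) for metabolic stability, with Liver microsome (Rattus norvegicus) as the target, using microsomes (on this read-out lower numbers stand for slow clearance and higher numbers for fast clearance), compound 1 `O=C(O)c1csc(-n2cc(-c3ccccc3)c3ccccc32)n1` gives 2400 mL/min/kg while compound 2 `O=C(O)c1csc(-n2nc(-c3ccccc3)c3ccc(F)cc32)n1` gives 337 mL/min/kg and compound 3 `O=C(O)c1csc(-n2nc(-c3cccc(F)c3)c3ccccc32)n1` gives 385 mL/min/kg as its number. Compound 3 therefore sits level with compound 2, within the usual scatter of repeat measurements, and compound 1 stands well above both, beyond that scatter.

Compound 4 `O=C(O)c1csc(-n2nc(-c3ccsc3)c3ccccc32)n1` has not yet been measured. It differs from compound 3 in one place: thiophen-3-yl in place of 3-fluorophenyl on an aromatic carbon of a five-membered aromatic ring with 2 nitrogen (thiophen-3-yl in place of 3-fluorophenyl on an aromatic carbon). Among the compounds with values here, no two measured compounds here differ in just one place, so no measured step shows directly what such a swap does, and any forecast is loose. Compound 4 shares that ring with compound 2 and compound 3 but not with compound 1, so compound 2 at 337 mL/min/kg and compound 3 at 385 mL/min/kg are closer guides than compound 1 at 2400 mL/min/kg in this small set. The estimated step of a 1.2-fold higher number from compound 3 to compound 4 (0.07 log units; within the scatter) is small and upward, and it is expected to stay within the scatter. For compound 4 the estimated clearance is 450 mL/min/kg with an expected range from 200 mL/min/kg to 1000 mL/min/kg on this read-out.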

Compound 4, clearance: 190 mL/min/kg
Beside the measured number, compound 4's estimate is 2.4-fold (0.37 log units) above it, and the stated range ends above it.
By their numbers in this assay, from the lowest: compounds 4, 2 and 3 (each within the scatter of the next, the first and the last beyond it); then compound 1.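

In this assay, replacing 3-fluorophenyl with thiophen-3-yl on the aromatic carbon of the five-membered ring with two nitrogens gives a 2.0-fold lower number from compound 3 to compound 4 (0.31 log units; beyond the scatter). This is the only pair shown that differs in just one place, so it gives the first direct sign that the group at this carbon, next to the ring nitrogen, can shift the clearance number, although the step is modest. The swap changes the ring size and the hetero atom and also removes the fluorine, and no measurement here explains the drop or separates these changes.

Going by these compounds, it remains open whether a plain phenyl, a furan-3-yl ring, a pyridine ring or a short alkyl chain at this carbon would give a lower or a higher number than thiophen-3-yl does. On these data alone, it is also open whether thiophen-3-yl would lower the number in the same way on the core of compound 1, which stands far above the others, or whether this step holds only on the core shared by compound 3 and compound 4.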